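The compounds below may be only part of what the source reports. "The series", "measured", "known", "first", "only" and "open" are said of these compounds alone.

Measured compounds:
- compound 1, `COc1cc(OC)c2c(=O)cc(-c3ccc(OCCN)cc3)oc2c1`: 6%
- compound 2, `COc1cc(OC)c2c(=O)cc(-c3ccc(OCC(O)CO)cc3)oc2c1`: "not active" (no number reported)
- compound 3, `COc1cc(OC)c2c(=O)cc(-c3ccc(-c4ccc(F)nc4)cc3)oc2c1`: "not active" (no number reported)

All three share one core and differ only in the group on the six-membered carbon ring attached to it. In a functional assay (Homo sapiens) for antiproliferative activity, read by resazurin assay, with a stated time of 48 h, tested at 5 uM (a higher number here means a stronger effect of the compound at the concentration tested, a lower number a weaker effect), compound 1 gives 6%, a reading that is small and within the usual scatter of this kind of measurement. For compound 2 this assay gives "not active" (no number reported), so no number was recorded. Compound 3, carrying a 6-fluoropyridin-3-yl group, stands at "not active" (no number reported) in this assay, again without a number; it stands no higher than compound 1, and nothing among the three compounds rises clearly above the scatter.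

Compound 4, `COc1cc(OC)c2c(=O)cc(-c3ccc(NCCN4CCCC4)cc3)oc2c1`, has not yet been measured. It differs from compound 3 in one place: (2-(pyrrolidin-1-yl)ethyl)amino in place of 6-fluoropyridin-3-yl on an aromatic carbon. Going by the values given here, no comparable pair among the measured compounds shows what such a change does in this assay, so no step size can be read off. Because compound 1 gives only 6% and compound 3 gives "not active" (no number reported), a change here is expected to stay within the scatter, in no particular direction. Compound 4 is therefore estimated at 8%, with a range from 0% to 25%.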

Compound 4, a percentage reported as inhibition, at one concentration (the size of the read-out at that concentration, not a potency): 21%
Compound 4: the middle estimate sits 13 percentage points below what was measured; low and high end bracket the measured number.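

In this assay, replacing 2-aminoethoxy with (2-(pyrrolidin-1-yl)ethyl)amino on the aromatic carbon gives a number 15 percentage points higher from compound 1 to compound 4 (beyond the scatter). Going by these compounds alone, this shows that the group at this position can move the reading past the usual scatter, which the earlier compounds could not show, since none of them rose clearly above it. No measurement here explains why this change has that effect.

The change alters two features at once, the atom linking the chain to the ring and the end of the chain, so the compounds shown leave open which of the two accounts for the step. A 2-(pyrrolidin-1-yl)ethoxy group or a (2-aminoethyl)amino group would separate the two features, while a piperidine ring or a longer chain would test how far the step extends.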